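The source may hold more compounds than are shown below. What is called first, only, known or untested is meant among the compounds shown, and "the series" means these compounds.

In a functional assay on MCF7 cells (Homo sapiens) for antiproliferative activity, read by sulforhodamine B assay, with a stated time of 48 h (a lower number here means a stronger inhibitor, a higher number a weaker inhibitor), compound 1 `Cc1cccc(OS(=O)(=O)c2ccc(N3CCN(C)C3=O)cc2)c1` gives 5100 nM. Compound 2 `CN1CCN(c2ccc(S(=O)(=O)Oc3cccc(F)c3)cc2)C1=O` carries fluoro in place of the methyl on the aromatic carbon, and it reads > 100000 nM, which is a limit of the assay and not a number. That change gives an at least 19-fold higher number from compound 1 to compound 2 (1.29 log units; beyond the scatter), a large step beyond the scatter. Compound 3 `CCCN1CCN(c2ccc(S(=O)(=O)Oc3cccc(C)c3)cc2)C1=O` instead has ethyl in place of hydrogen on the saturated chain carbon bound to the amide-type nitrogen in the ring, and it gives 86000 nM. This is a 17-fold higher number from compound 1 to compound 3 (1.23 log units; beyond the scatter), also large. Of the two values that are true numbers, compound 3 holds the higher, so it is the weaker of that pair.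

Compound 4 `CCCN1CCN(c2ccc(S(=O)(=O)Oc3ccc(Cl)cc3)cc2)C1=O` differs from compound 3 only on the oxygen bound to the sulfonyl sulfur, with 4-chlorophenyl in place of 3-methylphenyl on an oxygen. The closest measured precedent is an at least 19-fold higher number from compound 1 to compound 2 (1.29 log units; beyond the scatter), where replacing the methyl cost much activity. Within the data shown here, that is only a weak guide, as no measured compound carries 4-chlorophenyl. With compound 3 already giving 86000 nM, no step beyond the scatter is expected in this assay, in either direction. The expected step is a 1.1-fold lower number from compound 3 to compound 4 (0.03 log units; within the scatter). For compound 4 the estimated value is 80000 nM, with an expected range from 25000 nM to 100000 nM.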

Compound 4, half-maximal inhibitory concentration: 18000 nM
Estimate against measurement, compound 4: 4.4-fold (0.65 log units) above; the measured number lies below the stated range.
By their numbers in this assay, from the lowest: compound 1; then compound 4; then compound 3. At a limit, above all of these: compound 2.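

In this assay, the step on the oxygen bound to the sulfonyl sulfur gives a 4.8-fold lower number from compound 3 to compound 4 (0.68 log units; beyond the scatter), a modest gain and the only change to this aryl group among the compounds shown that lowers the number, so this position is not simply one where any replacement of the 3-methylphenyl group costs activity. The gain comes with no change in what is counted here: 3-methylphenyl and 4-chlorophenyl have the same number of heavy atoms, and neither has a hydrogen-bond donor or acceptor, so the difference lies in which group is present and where it is attached on the ring. The contrasting fluoro compound gives no number to compare with, since compound 2 reads only as a limit of the assay: the limit of > 100000 nM in this assay, at which 1 of the 4 values shown sits.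

Because chlorine and its ring position change together, these compounds cannot show which of the two matters, and a 3-chlorophenyl or 4-methylphenyl group on the same oxygen would separate them. Also open, from the compounds shown here alone, is whether the gain carries over to the core of compound 1, or to a ring bearing an amine or a carboxylic acid.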